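This account rests on a few compounds, and the source may have more. Where it says the series, first, only, none or still open, it means among the compounds named here.

In an ADME assay on NIH3T3 cells (Mus musculus) for cytotoxicity, read by MTT assay, with a stated time of 24 h (on this read-out higher numbers stand for weaker inhibition and lower numbers for stronger inhibition), compound 1 `Cn1cnnc1SCC(=O)N/N=c1/scc(-c2ccc(C#N)cc2)n1-c1ccccc1` gives 153 ug/mL and compound 2 `Cn1nnnc1SCC(=O)N/N=c1/scc(-c2ccc(C#N)cc2)n1-c1ccccc1` gives 213 ug/mL so the two stand level within the scatter. Compound 3 `Cn1cnnc1SCC(=O)N/N=c1/scc(-c2ccc(Cl)cc2)n1-c1ccccc1` differs from compound 1 by chloro in place of cyano on an aromatic carbon with chloro in place of cyano on an aromatic carbon. Within the data shown here, the only measured step of a 1.4-fold higher number from compound 1 to compound 2 (0.14 log units; within the scatter) lies within the scatter and sits at the group on a sulfur, so it says little about the aromatic carbon changed here. No step beyond the scatter is expected in this assay and no direction is favoured. The estimated step of a 1.1-fold lower number from compound 1 to compound 3 (0.04 log units; within the scatter) is correspondingly small. Compound 3 is expected at 140 ug/mL with an estimated range from 65 ug/mL to 300 ug/mL on this read-out.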

Compound 3, half-maximal inhibitory concentration: 51.7 ug/mL
Estimate against measurement, compound 3: 2.7-fold (0.43 log units) above; the whole stated range lies above it.
By their numbers in this assay, from the lowest: compound 3; then compounds 1 and 2 (each within the scatter of the next).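

In this assay the aromatic carbon para to a large group is sensitive to change: chloro in place of cyano gives a 3.0-fold lower number from compound 1 to compound 3 (0.47 log units; beyond the scatter), the only step shown beyond the scatter. The change at the group on a sulfur gave only a 1.4-fold higher number from compound 1 to compound 2 (0.14 log units; within the scatter). Nothing available explains the shift at the aromatic carbon.

As far as these compounds go, whether other groups at this position, such as an amine or a carboxylic acid, also lower the number remains open. Also open, from the compounds shown here alone, is whether the same change would give a similar step with the 1-methyl-1H-tetrazol-5-yl group of compound 2.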